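Chain and heteroaryl variation on a shared dicyano core

This account rests on a few compounds, and the source may have more. Where it says the series, first, only, none or still open, it means among the compounds named here.

Measured so far:
compound 1 `CN(C)CCCn1c(N)c(-c2nc3ccccc3s2)c2nc(C#N)c(C#N)nc21`: 1800 nM
compound 2 `CN(C)CCCCn1c(N)c(-c2nc3ccccc3s2)c2nc(C#N)c(C#N)nc21`: 1330 nM

In a functional assay on K562 cells (Homo sapiens) for antiproliferative activity, read by MTT assay, with a stated time of 48 h (a lower number here means a stronger inhibitor, a higher number a weaker inhibitor), compound 1 gives 1800 nM and compound 2 gives 1330 nM. Among the compounds with values here, the one measured step, a 1.4-fold lower number from compound 1 to compound 2 (0.13 log units; within the scatter), changes only the length of the chain on the ring nitrogen and stays inside the scatter, so the two numbers cannot be ordered. Compound 2 has the lowest of the two numbers, with compound 1 nearest and within the scatter of it.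

Compound 3 `CN(C)CCCCn1c(N)c(-c2nc3cc(Cl)ccc3[nH]2)c2nc(C#N)c(C#N)nc21` is not yet measured. It differs from compound 2 in one place: 5-chloro-1H-benzimidazol-2-yl in place of 1,3-benzothiazol-2-yl on an aromatic carbon. Within the data shown here, no measured step touches this position; the only step in hand concerns the chain, not the heteroaryl group, and it bears no information on the exchange made here. On these data alone, with nothing to lean on beyond compound 2 itself, the expectation is that compound 3 stays near compound 2 in this assay, with no step beyond the scatter expected, a 1.1-fold higher number from compound 2 to compound 3 (0.05 log units; within the scatter), but with a wide range because the change is untested. For compound 3 the estimate is 1500 nM, from 400 nM to 6000 nM.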

Compound 3, half-maximal inhibitory concentration: 1930 nM
For compound 3 the middle estimate is 1.3-fold (0.11 log units) below the measured one; the range from low to high includes it.
By their numbers in this assay, from the lowest: compounds 2, 1 and 3 (each within the scatter of the next).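

In this assay, within the data shown here, the first reading at this position, on an aromatic carbon next to the ring atom that bears an amino group, is a 1.5-fold higher number from compound 2 to compound 3 (0.16 log units; within the scatter), so 5-chloro-1H-benzimidazol-2-yl and 1,3-benzothiazol-2-yl cannot be ordered here. The exchange puts nitrogen where the ring held sulfur, adds a chlorine and brings in a hydrogen-bond donor where the leaving group has none, yet the two numbers stay within the scatter of each other, so with the 4-(dimethylamino)butyl chain in place this position accepts this particular exchange without a readable shift. Nothing in hand gives a reason for this outcome.

Among these compounds, the single step carries the ring exchange and the chlorine together, so the two cannot be told apart without the unsubstituted 1H-benzimidazol-2-yl group as a comparison. Also open, on these data alone, are whether a simple phenyl or pyridin-2-yl group at this position stays within the scatter of compound 2, and whether 5-chloro-1H-benzimidazol-2-yl behaves the same way on the shorter chain of compound 1.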